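Bromo on compound 2: expected step in cytotoxicity

This account rests on a few compounds, and the source may have more. Where it says the series, first, only, none or still open, it means among the compounds named here.

In an ADME assay on HEK-293T cells (Homo sapiens) for cytotoxicity, with a stated time of 48 h (on this read-out higher numbers stand for lower toxicity in this test and lower numbers for higher toxicity in this test), compound 1 `CCC(Nc1cc(C)ncn1)c1ccc(Oc2ccc(F)cc2)cc1` gives > 10000 nM as a limit of the assay. Compound 2 `CCCc1cc(NC(CC)c2ccc(Oc3ccc(F)cc3)cc2)ncn1` gives > 10000 nM as a limit too. Compound 3 `CCC(Nc1cc(COC)ncn1)c1ccc(Oc2ccc(F)cc2)cc1` gives > 10000 nM as a limit too. With the limit of > 10000 nM in this assay, at which 3 of the 3 values shown sit, in view compound 2 has no number of its own.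

Compound 4 `CCCc1ncnc(NC(CC)c2ccc(Oc3ccc(F)cc3)cc2)c1Br` carries bromo in place of hydrogen on an aromatic carbon of compound 2, and the difference is bromo in place of hydrogen on an aromatic carbon in full.

The nearest measured steps are a step that the two limits leave unreadable from compound 1 to compound 2 and a step that the two limits leave unreadable from compound 1 to compound 3 and a step that the two limits leave unreadable from compound 2 to compound 3 and none has a readable size. All three change a saturated chain carbon and none places bromo on an aromatic carbon, so they offer no size to carry over.

No step beyond the usual scatter is therefore expected in this assay and no direction is favoured. The expected step is a step that the limit leaves unreadable from compound 2 to compound 4 on this reasoning. Compound 4 is estimated at 15000 nM with a range from 6000 nM to 40000 nM and is expected to be reported most likely as a limit again.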

Compound 4, half-maximal cytotoxic concentration: > 10000 nM
Compound 4: only a limit was reported; the forecaster's own chance of this, stated with the estimate: 80%; the middle value does not contradict the limit.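

No step can be read from compound 2 to compound 4 in this assay, as both are reported only as limits. The compounds shown leave open the actual half-maximal cytotoxic concentration of each compound, and whether bromo in place of hydrogen on an aromatic carbon changes it at all.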